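From Benzylsulfanyl to Methoxy: an Unmeasured Cytotoxicity Step

The source may report more compounds than this note shows. Statements on the series, on what has been measured and on what is new or still open speak of the compounds shown alone.

Three analogues share one core. Compound 3 `OC[C@H]1O[C@@H](n2cnc3c(CSCc4ccccc4)ncnc32)[C@H](O)[C@@H]1O` gives in a functional assay on Huh-7 cells (Homo sapiens) for cytotoxicity, read by MTT assay, with a stated time of 3 days (on this read-out higher numbers stand for lower toxicity in this test and lower numbers for higher toxicity in this test), only a limit, > 100000 nM. Compound 2 `OC[C@H]1O[C@@H](n2cnc3c(CSc4ccccc4)ncnc32)[C@H](O)[C@@H]1O` likewise gives only a limit, > 100000 nM. Compound 1 `OC[C@H]1O[C@@H](n2cnc3c(COc4ccccn4)ncnc32)[C@H](O)[C@@H]1O` also gives only a limit, > 250000 nM. The two thresholds are the limit of > 100000 nM in this assay, at which 2 of the 3 values shown sit, and (the limit of > 250000 nM in this assay, at which 1 of the 3 values shown sits), so compound 3 sits at the lower of them with no number of its own. Compound 4 `COCc1ncnc2c1ncn2[C@@H]1O[C@H](CO)[C@@H](O)[C@H]1O` carries methoxy in place of benzylsulfanyl on a saturated chain carbon bound to an aromatic carbon. The steps a step that the two limits leave unreadable from compound 1 to compound 2, a step that the two limits leave unreadable from compound 1 to compound 3 and a step that the two limits leave unreadable from compound 2 to compound 3 are all unreadable in size, so they give no direction and no size for the change to compound 4, and no step beyond the scatter is expected. Compound 4 is therefore expected at 200000 nM, between 100000 nM and 400000 nM, an expected step that the limit leaves unreadable from compound 3 to compound 4, most likely reported again as a limit.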

Compound 4, half-maximal cytotoxic concentration: > 100000 nM
Compound 4 gave a limit, no number; the forecaster's own chance of this, stated with the estimate: 85%; the middle value lies beyond the limit too.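

Going by these compounds alone, compound 4 gives only a limit, > 100000 nM, so no step from compound 1, compound 2 or compound 3 to compound 4 can be read. The compounds shown leave open what actual number any of the four would reach in this assay.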